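Adding a second fluorine to a dimethylamino tolan

The compounds below may be only part of what the source reports. "The series", "measured", "known", "first", "only" and "open" are said of these compounds alone.

For the measured compounds named here, compound 2 `CN(C)c1ccc(C#Cc2ccccc2F)cc1` is one of two compounds measured in a functional assay on LS174T cells (Homo sapiens) for antiproliferative activity, with a stated time of 4 days (on this read-out lower numbers stand for stronger inhibition and higher numbers for weaker inhibition), and in this assay compound 2 gives 39 nM, the higher of the two numbers. Compound 1 `CNc1ccc(C#Cc2c(F)cccc2F)cc1` carries a methylamino group in place of the dimethylamino group and a second fluoro group, and in this assay compound 1 gives 23 nM; the two values lie within the usual scatter of each other, so no order can be drawn from them. Compound 3 `CN(C)c1ccc(C#Cc2c(F)cccc2F)cc1` has not yet been measured. It differs from compound 2 by fluoro in place of hydrogen on an aromatic carbon. Going by the values given here, no pair of measured compounds isolates this change, and the only comparison available, compound 1 against compound 2, differs in two places at once. The step from compound 2 to compound 3 is therefore expected to be small, a 1.4-fold lower number from compound 2 to compound 3 (0.14 log units; within the scatter), not beyond the scatter in either direction. Compound 3 is estimated to give 28 nM in this assay, within a range of 9 nM to 85 nM.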

Compound 3, half-maximal inhibitory concentration: 23 nM
Compound 3: middle estimate off by 1.2-fold (0.09 log units), on the high side, within the range that was stated.
By their numbers in this assay, from the lowest: compounds 1, 3 and 2 (each within the scatter of the next).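

For the compounds shown here, compound 3 separates the two changes that were tied together in the only earlier comparison. In this assay fluoro in place of hydrogen on an aromatic carbon, ortho to a large group, gives a 1.7-fold lower number from compound 2 to compound 3 (0.23 log units; within the scatter) and methyl in place of hydrogen on a nitrogen on an aromatic ring gives no change at the digits printed from compound 1 to compound 3 (within the scatter) so neither change taken alone moves the number beyond the scatter. No measurement shown here bears on the reason for the size of these two steps.

As far as these compounds go, what chloro, methoxy or a nitrile would do at this position remains open, and so does whether a larger group there would give a step beyond the scatter. From the compounds shown here alone, on the nitrogen, the effect of an ethyl chain or of a second, longer alkyl chain also remains open.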